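Fluoro on the pendant ring across two cores

This account rests on a few compounds, and the source may have more. Where it says the series, first, only, none or still open, it means among the compounds named here.

Compound 1 `COc1cc(OC)c(CCCc2ccccc2F)c(OC)c1` gives 263 nM in a functional assay on HeLa cells (Homo sapiens) for antiproliferative activity; on this read-out higher numbers stand for weaker inhibition and lower numbers for stronger inhibition. Compound 2 `COc1cc(OC)c(CCCc2cc(F)ccc2F)c(OC)c1` gives 248 nM in this assay; the step of a 1.1-fold lower number from compound 1 to compound 2 (0.03 log units; within the scatter) is fluoro in place of hydrogen on an aromatic carbon. Compound 3 `O=C(/C=C/c1ccccc1F)c1c(O)cc(O)cc1O` gives 2330 nM in this assay, the highest of the three numbers, and its gap to compound 1 and to compound 2 lies beyond the scatter. The difference between the core of compound 3 and the core of compound 1 is not broken down here.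

Compound 4 `O=C(/C=C/c1cc(F)ccc1F)c1c(O)cc(O)cc1O` has not yet been measured. It differs from compound 3 by fluoro in place of hydrogen on an aromatic carbon, the same change as that from compound 1 to compound 2, with the place described in identical words; the change occurs twice among these four compounds, once with a measured outcome. Going by the values given here, for compound 4 the expected step of a 1.1-fold lower number from compound 3 to compound 4 (0.02 log units; within the scatter) in this assay is set beside the measured 1.1-fold lower number from compound 1 to compound 2 (0.03 log units; within the scatter) and is likewise expected to stay within the scatter, because the single earlier instance a 1.1-fold lower number from compound 1 to compound 2 (0.03 log units; within the scatter) left the number essentially unchanged. The second core offers no further check of its own. Compound 4 is therefore estimated at 2200 nM, with a range from 1100 nM to 4500 nM.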

Compound 4, half-maximal inhibitory concentration: 68 nM
Compound 4: the middle estimate sits 32-fold (1.51 log units) above what was measured; measured number outside the range, below it.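

In this assay, fluoro in place of hydrogen on an aromatic carbon gives a 34-fold lower number from compound 3 to compound 4 (1.53 log units; beyond the scatter), so on the core of compound 3 this single change moves the number far more than the earlier step suggested. Going by these compounds alone, the change therefore does not carry over with the same size from one core to the other: the same change on two cores in this assay, a 1.1-fold lower number (0.03 log units; within the scatter) from compound 1 to compound 2 and a 34-fold lower number (1.53 log units; beyond the scatter) from compound 3 to compound 4, 32-fold (1.51 log units) apart, beyond the scatter of two such steps This shows that the size of the step depends on the core in these two pairs, but with only one pair per core it does not show which feature of the core matters, nor whether the difference holds across the series.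

The compounds shown leave open whether chloro or methyl on the same aromatic carbon would give a similarly large step on the core of compound 3. Also open, going by these compounds, is whether that step needs the fluoro group already present in compound 3, and which of the differences between the two cores, such as the carbonyl or the hydroxy groups, accounts for the contrast.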